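The compounds below may be only part of what the source reports. "The series", "measured", "known", "first", "only" and "open" are said of these compounds alone.

Two compounds share one core and differ only in the arrangement of the fused five-membered ring. Compound 1 `O=C1CC(c2ccccc2F)n2ccnc2N1` and compound 2 `O=C1CC(c2ccccc2F)n2nccc2N1` were both tested in a functional assay on the whole organism (strain Kunming) with Mus musculus as the target; on this read-out lower numbers stand for an effect already at smaller amounts and higher numbers for an effect only at larger amounts of compound. In this assay compound 1 gives 88 mg/kg, while compound 2 gives 47.3 mg/kg. Compound 2 thus carries the lower of the two numbers, but the gap to compound 1 lies within the usual scatter of such measurements, so the two compounds cannot be told apart on this read-out.

Compound 3 `O=C1CC(c2ccccc2Br)n2nccc2N1` keeps the core of compound 2 and changes only the substituent on the phenyl ring: bromo in place of fluoro on an aromatic carbon. Going by the values given here, no measured pair shows what this exchange does in this assay, so the expectation rests on compound 2 alone. Since nothing in the data points to a particular direction, the step is expected to stay small, and the estimate for compound 3 in this assay is 45 mg/kg, with a range from 20 mg/kg to 100 mg/kg. The step this estimate means, a 1.1-fold lower number from compound 2 to compound 3 (0.02 log units; within the scatter), is expected to fall within the scatter.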

Compound 3, dose for half-maximal effect: 39.4 mg/kg
Compound 3: the middle estimate sits 1.1-fold (0.06 log units) above what was measured; the measured number falls inside the stated range.
By their numbers in this assay, from the lowest: compounds 3, 2 and 1 (each within the scatter of the next, the first and the last beyond it).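

In this assay, going by these compounds alone, bromo in place of fluoro on an aromatic carbon gives a 1.2-fold lower number from compound 2 to compound 3 (0.08 log units; within the scatter) and so provides the first step that can be read at this position, where compound 1 and compound 2 had differed only in the fused five-membered ring. On this read-out compound 3 cannot be told apart from compound 2, so at this place, ortho to a large group, the two halogens give no difference that the measurement can resolve, although this rests on a single pair. Nothing measured here gives a reason for this outcome.

The compounds shown leave open whether the same position would read alike with a group other than a halogen, such as a methoxy group, an amine or a carboxylic acid, and whether any exchange there can produce a step beyond the scatter. Also open, from the compounds shown here alone, is whether bromo in place of fluoro would read the same way on the core of compound 1, and whether the result holds for other places on the phenyl ring.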